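A few compounds are considered here, and "the series" means these few. Any claim that something is new, unique, unknown or untested is made for them only; others in the source may bear on it.

Among the compounds with values here, compound 1, with the structure `C#CCNC1CCc2c(SCCc3cccc(Br)c3)cccc21`, stands at the lowest of the two numbers measured so far. In an ADME assay on isolated protein for inhibition of Amine oxidase [flavin-containing] B (Homo sapiens) (on this read-out lower numbers stand for stronger inhibition and higher numbers for weaker inhibition), compound 1 gives 620 nM. Within the data shown here, the only other measured compound, compound 2, `C#CCNC1CCc2c(SCc3cccc(F)c3)cccc21`, gives 11600 nM in this assay, a much higher number than compound 1 shows; no step between these two is counted here, so the pair tells only that compound 1 sits far below compound 2.

Compound 3, `C#CCNC1CCc2c(SCCc3ccc(OC)cc3)cccc21`, has not yet been measured. It differs from compound 1 in one place: 4-methoxyphenyl in place of 3-bromophenyl on a saturated chain carbon, two bonds along the chain from a sulfur. Among the measured compounds shown here, no measured pair in this set shares this kind of change, so there is no counted step to lean on; the expectation rests on the two values alone and on the change itself.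

The account expects compound 3 to show a somewhat higher number than compound 1 in this assay, a step of a 2.4-fold higher number from compound 1 to compound 3 (0.38 log units; beyond the scatter), which would lie beyond the scatter but remain well short of where compound 2 sits. On that basis compound 3 is estimated at 1500 nM, with a range from 400 nM to 6000 nM.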

Compound 3, half-maximal inhibitory concentration: 4590 nM
For compound 3 the middle estimate is 3.1-fold (0.49 log units) below the measured one; measured number inside the range.
By their numbers in this assay, from the lowest: compound 1; then compound 3; then compound 2.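

In this assay, within the data shown here, replacing 3-bromophenyl with 4-methoxyphenyl on a saturated chain carbon, two bonds along the chain from a sulfur, gives a 7.4-fold higher number from compound 1 to compound 3 (0.87 log units; beyond the scatter) and so provides the first counted step in this set. It shows that, with the chain and the shared core unchanged, this position responds to a change in the terminal aromatic group, and that this particular change moves the number toward weaker inhibition. No measurement in hand explains the size or direction of this step, so it cannot be assigned to any one feature of the two groups.

Because the bromine is exchanged for methoxy while the substituent also moves from the 3-position to the 4-position of the phenyl ring, the compounds shown leave open whether the step follows the identity of the substituent, its place, or both, a question that 4-bromophenyl and 3-methoxyphenyl would separate. They also leave open how this position would respond to a group of another kind, such as an unsubstituted phenyl, a pyridine ring or a carboxylic acid, or to a longer chain carrying the same 3-bromophenyl.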